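Cytotoxicity notes on the shared-core series

The source may hold more compounds than are shown below. What is called first, only, known or untested is meant among the compounds shown, and "the series" means these compounds.

Measured compounds:
compound 1 `Cc1ccccc1CNc1nn(-c2ccc(F)cc2F)cc1CNCCN1CCN(C)CC1`, > 20000 nM
compound 2 `CN1CCN(CCNCc2cn(-c3ccc(C(F)(F)F)cc3)nc2-c2ccc(C(F)(F)F)cc2)CC1`, 1500 nM
compound 3 `Cc1ccccc1-c1nn(-c2ccc(C(F)(F)F)cc2)cc1CNCCN1CCN(C)CC1`, 11000 nM

In an ADME assay on Huh-7 cells (Homo sapiens) for cytotoxicity (on this read-out lower numbers stand for higher toxicity in this test and higher numbers for lower toxicity in this test), compound 1 gives only a limit, > 20000 nM, and no number, as noted in the limit of > 20000 nM in this assay, at which 1 of the 3 values shown sits. Compound 2 gives 1500 nM in this assay and compound 3 gives 11000 nM. Going by the values given here, the one measured step, a 7.3-fold higher number from compound 2 to compound 3 (0.87 log units; beyond the scatter), concerns a different group than the change now followed. Compound 4 `CN1CCN(CCNCc2cn(-c3ccc(F)cc3F)nc2-c2ccc(Cl)cc2)CC1` differs from compound 1 by 4-chlorophenyl in place of (2-methylbenzyl)amino on an aromatic carbon. Among the compounds with values here, no measured step matches this change, so the guide is loose. Because compound 2 gives 1500 nM with an aryl group at the same place, compound 4 is expected to land between compound 2 and compound 3, a step of an at least 4.0-fold lower number from compound 1 to compound 4 (0.60 log units; beyond the scatter). The estimate for compound 4 is 5000 nM, between 1500 nM and 20000 nM.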

Compound 4, half-maximal cytotoxic concentration: 19000 nM
For compound 4 the middle estimate is 3.8-fold (0.58 log units) below the measured one; the measured number falls inside the stated range.
By their numbers in this assay, from the lowest: compound 2; then compounds 3 and 4 (each within the scatter of the next). At a limit, above all of these: compound 1.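

At this position, 4-chlorophenyl in place of (2-methylbenzyl)amino gives an at least 1.0-fold lower number from compound 1 to compound 4 (0.02 log units; that floor lies within the scatter). The entering group counts no hydrogen-bond donor where the leaving group counts one, yet in this assay the floor of this step stays within the scatter. Compound 1 stands at a limit, so only that floor can be read: the limit of > 20000 nM in this assay, at which 1 of the 4 values shown sits.

Open, on these data alone, is how a carboxylic acid or a morpholine at this position would read. Also open, as far as these compounds go, is whether 4-chlorophenyl would read the same with 4-(trifluoromethyl)phenyl in place of the 2,4-difluorophenyl group.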